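A few compounds are considered here, and "the series" means these few. Any claim that something is new, unique, unknown or untested is made for them only; others in the source may bear on it.

In a toxicity assay on MDCK cells (Canis lupus familiaris) for cytotoxicity, read by CCK-8 assay, with a stated time of 48 h (on this read-out higher numbers stand for lower toxicity in this test and lower numbers for higher toxicity in this test), compound 3 (`COc1ccc(C(=O)NNc2c(F)cccc2F)cc1`) reads > 100000 nM, a limit of the assay and not a number. Compound 2 (`CCOc1ccc(C(=O)NNc2c(F)cccc2F)cc1`) reads > 100000 nM, likewise a limit. Compound 1 (`CN(C)c1ccc(C(=O)NNc2c(Cl)cccc2Cl)cc1`) reads > 100000 nM, again a limit. The series therefore sits wholly at the limit of > 100000 nM in this assay, at which 3 of the 3 values shown sit, and compound 3 has no readable place within it beyond that limit.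

The next compound to be read is compound 4 (`CN(C)c1ccc(C(=O)NNc2c(F)cccc2F)cc1`), with dimethylamino in place of methoxy on an aromatic carbon, para to a large group: dimethylamino in place of methoxy on an aromatic carbon. Among the measured compounds shown here, the only measured step, a step that the two limits leave unreadable from compound 2 to compound 3, concerns a different change and gives no size to carry over. The nearest support is compound 1, which also carries dimethylamino and reads > 100000 nM. That reading is a limit as well, so it bounds the expectation without sizing it. No step beyond the scatter is expected in this assay, in either direction, and the estimated change is a number no higher from compound 3 to compound 4 (the limit leaves the size open). Compound 4 is estimated at 100000 nM, with an expected range from 50000 nM to 200000 nM, and the result will most probably be reported only as a limit.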

Compound 4, half-maximal cytotoxic concentration: > 100000 nM
Compound 4 gave a limit, no number; the forecaster's own chance of this, stated with the estimate: 85%; the middle value sits exactly at the limit.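

Among the compounds shown here, compound 2, compound 3 and compound 4 all read as limits, not numbers, in this assay, and no step among them can be read: the limit of > 100000 nM in this assay, at which 4 of the 4 values shown sit.

The compounds shown leave open whether ethoxy, methoxy and dimethylamino differ at all in this assay, and no compound here marks where toxicity would begin to give a number.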